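Swapping a Fluorophenyl Tail for a Methylthiophene Tail

The source may hold more compounds than are shown below. What is called first, only, known or untested is meant among the compounds shown, and "the series" means these compounds.

Compound 3 `Cc1nc(C)c([C@H](OC(C)(C)C)C(=O)O)c(N2CCC(C)(C)CC2)c1-c1ccc(CCCc2ccc(F)cc2)cc1` carries a 3-(4-fluorophenyl)propyl group on an aromatic carbon of its core. In a toxicity assay on MT2 cells (Homo sapiens) for cytotoxicity, read by XTT assay, with a stated time of 4 days (a lower number here means that less compound is tolerated, a higher number that more compound is tolerated), compound 3 gives >= 32000 nM, which is a limit of the assay rather than a measured number. Its two close relatives are no more readable. Compound 1 `Cc1ccc(CCOc2ccc(-c3c(C)nc(C)c([C@H](OC(C)(C)C)C(=O)O)c3N3CCC(C)(C)CC3)cc2)cc1` gives in this assay >= 33500 nM, again only a limit. Compound 2 `Cc1nc(C)c([C@H](OC(C)(C)C)C(=O)O)c(N2CCC(C)(C)CC2)c1-c1ccc(OCCc2ccc(F)c(F)c2)cc1` gives >= 33500 nM, also a limit. Every value therefore sits at the limit of >= 32000 nM in this assay, at which 1 of the 3 values shown sits, or at the limit of >= 33500 nM in this assay, at which 2 of the 3 values shown sit, and the steps a step that the two limits leave unreadable from compound 1 to compound 2, a step that the two limits leave unreadable from compound 1 to compound 3 and a step that the two limits leave unreadable from compound 2 to compound 3 cannot be sized; they show only that none of the three tails lowered the tolerated concentration into the readable range.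

Compound 4 `Cc1ccc(CCOc2ccc(-c3c(C)nc(C)c([C@H](OC(C)(C)C)C(=O)O)c3N3CCC(C)(C)CC3)cc2)s1` differs from compound 3 by 2-(5-methylthiophen-2-yl)ethoxy in place of 3-(4-fluorophenyl)propyl on an aromatic carbon. Since every tail exchanged so far left the value at a limit, compound 4 is expected to behave the same way, with an estimate of 40000 nM (from 20000 nM to 100000 nM). The expected step is a step that the limit leaves unreadable from compound 3 to compound 4, meaning no change beyond the scatter, and most probably another limit.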

Compound 4, half-maximal cytotoxic concentration: >= 25000 nM
Compound 4 ended at the assay's limit; the forecaster's own chance of this, stated with the estimate: 80%; the middle value lies beyond the limit too.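

Compound 4 also gives only a limit in this assay, so its steps from compound 1, compound 2 and compound 3 cannot be read. The compounds shown leave open at what concentration each becomes toxic to these cells, and whether exchanging the tail changes that concentration at all.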